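Fluoro for Hydrogen on a Fused Aromatic Ring: Two Pairs

This account rests on a few compounds, and the source may have more. Where it says the series, first, only, none or still open, it means among the compounds named here.

Measured so far:
Compound 1, `COc1ccc(-c2cc(C(=O)Nc3ccc(Oc4ccnc5cc(OCCCN6CCCCC6)c(OC)cc45)c(F)c3)c3ccccc3n2)cc1`, gives 290 nM.
Compound 2, `COc1cc2c(Oc3ccc(NC(=O)c4cc(-c5cccc(Cl)c5)nc5ccccc45)cc3F)ccnc2cc1OCCCN1CCC(C)CC1`, gives 65 nM.
Compound 3, `COc1ccc(-c2cc(C(=O)Nc3ccc(Oc4ccnc5cc(OCCCN6CCCCC6)c(OC)cc45)c(F)c3)c3cc(F)ccc3n2)cc1`, gives 240 nM.

These three numbers come from a functional assay on NCI-H460 cells (Homo sapiens) for cytotoxicity, read by MTT assay, with a stated time of 72 h; a lower number here means a stronger inhibitor, a higher number a weaker inhibitor. Compound 3 arises from compound 1 by fluoro in place of hydrogen on an aromatic carbon, and that step gave a 1.2-fold lower number from compound 1 to compound 3 (0.08 log units; within the scatter). Compound 2 differs from compound 1 in more than one place; the difference between the two cores is not broken down here. Compound 2 has the lowest number of the three, and its steps to compound 3 and to compound 1 both lie beyond the scatter.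

Compound 4, `COc1cc2c(Oc3ccc(NC(=O)c4cc(-c5cccc(Cl)c5)nc5ccc(F)cc45)cc3F)ccnc2cc1OCCCN1CCC(C)CC1`, has not yet been measured in this assay. For the measured compounds named here, it arises from compound 2 by fluoro in place of hydrogen on an aromatic carbon, which is the same change as the one from compound 1 to compound 3. Because the earlier pair shows a 1.2-fold lower number from compound 1 to compound 3 (0.08 log units; within the scatter), the step expected from this change is estimated at a 1.2-fold lower number from compound 2 to compound 4 (0.07 log units; within the scatter). In this assay compound 4 is therefore expected to give about 55 nM, with a likely range from 25 nM to 130 nM.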

Compound 4, half-maximal inhibitory concentration: 60 nM
For compound 4 the middle estimate is 1.1-fold (0.04 log units) below the measured one; the measured number falls inside the stated range.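

In this assay, fluoro in place of hydrogen on an aromatic carbon of the fused ring system gave a 1.1-fold lower number from compound 2 to compound 4 (0.03 log units; within the scatter), so on this second core, too, the change left the number within the scatter. The two steps agree, and in this series the small size of the step carried over between two cores that differ in more than one place: the same change on two cores in this assay, a 1.2-fold lower number (0.08 log units; within the scatter) from compound 1 to compound 3 and a 1.1-fold lower number (0.03 log units; within the scatter) from compound 2 to compound 4, 1.1-fold (0.05 log units) apart, within the scatter of two such steps. For the compounds shown here, this rests on only two pairs and shows a step too small to read on either core, so it does not show that fluoro has any effect of its own in this assay, and it does not establish that the result would hold on any further core.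

The compounds shown leave open whether a different group on that same aromatic carbon, such as a nitrile or a dimethylamino group, would give a step beyond the scatter. They also leave open whether such a step would carry from one core to the other as closely as the fluoro step does.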